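Swapping thiophen-2-yl for thiophen-3-yl: an expected cytotoxicity

The source may report more compounds than this note shows. Statements on the series, on what has been measured and on what is new or still open speak of the compounds shown alone.

In a functional assay on MT2 cells (Homo sapiens) for cytotoxicity, read by MTT assay (on this read-out higher numbers stand for lower toxicity in this test and lower numbers for higher toxicity in this test), compound 2 `Clc1ccc(Nc2nccs2)cc1OCc1cccs1` gives 38000 nM and so stands within the scatter of compound 1 `CC(C)=CCOc1cc(Nc2nccs2)ccc1Cl` at 26000 nM in this test. Compound 3 `Clc1ccc(Nc2nccs2)cc1OCc1ccsc1` carries thiophen-3-yl in place of thiophen-2-yl on a saturated chain carbon bound to an oxygen on an aromatic ring. Going by the values given here, the one measured step at that place is a 1.5-fold higher number from compound 1 to compound 2 (0.16 log units; within the scatter) and it stayed within the scatter, while no measurement yet tests this exact swap. The expected size of a 1.1-fold lower number from compound 2 to compound 3 (0.04 log units; within the scatter) in this assay is therefore nothing beyond the scatter. Compound 3 is estimated at 35000 nM with a range from 17000 nM to 70000 nM for a measurement.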

Compound 3, half-maximal cytotoxic concentration: 38000 nM
Compound 3: the middle estimate sits 1.1-fold (0.04 log units) below what was measured; low and high end bracket the measured number.
By their numbers in this assay, from the lowest: compounds 1, 2 and 3 (each within the scatter of the next).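

In this assay the sulfur ring can be attached through either of its two ring positions, with no change at the digits printed from compound 2 to compound 3 (within the scatter) here. Replacing 2-methylprop-1-en-1-yl with thiophen-3-yl gives a 1.5-fold higher number from compound 1 to compound 3 (0.16 log units; within the scatter) as well, so all three groups at this place read alike in this test. Nothing available explains why these numbers agree. The compounds shown leave open whether an amine or a carboxylic acid at this place would move the number beyond the scatter. From the compounds shown here alone, a longer chain between the oxygen and the thiophene also remains open.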